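From Methyl to Chloro in Three Close Values

This account rests on a few compounds, and the source may have more. Where it says the series, first, only, none or still open, it means among the compounds named here.

compound 1 `COc1ccc(C2=NN(C3=NC(c4ccccc4)CS3)C(c3cccc4ccccc34)C2)cc1` gives 9510 nM
compound 2 `Cc1ccc(C2=NN(C3=NC(=O)CS3)C(c3ccc4ccccc4c3)C2)cc1` gives 7790 nM
compound 3 `Cc1ccc(C2=NN(C3=NC(c4ccccc4)CS3)C(c3ccc4ccccc4c3)C2)cc1C` gives 6570 nM

In a functional assay on BGC-823 cells (Homo sapiens) for inhibition, read by CCK-8 assay, with a stated time of 48 h (on this read-out lower numbers stand for stronger inhibition and higher numbers for weaker inhibition), compound 2 gives 7790 nM and cannot be ranked against the other two, as all three values lie within the usual scatter of repeated measurements of one another.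

Compound 4 `O=C1CSC(N2N=C(c3ccc(Cl)cc3)CC2c2ccc3ccccc3c2)=N1` is compound 2 with one change, from 4-methylphenyl to 4-chlorophenyl: chloro in place of methyl on an aromatic carbon, para to a large group (chloro in place of methyl on an aromatic carbon).

For the measured compounds named here, the measured compounds include no pair that differs in only one place, so no direct example of this swap exists in this assay to serve as a guide. The values do span a narrow range. Compound 1 (9510 nM) and compound 3 (6570 nM) each differ from compound 2 in several places, yet both stay within the scatter of compound 2 (7790 nM). Three compounds are thin evidence, but this single swap is expected to give no step beyond the scatter, and no firm direction can be expected. The estimate amounts to a 1.2-fold lower number from compound 2 to compound 4 (0.08 log units; within the scatter) and so stays within the scatter. For compound 4 the estimated value is 6500 nM (expected range 3000 nM to 13000 nM).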

Compound 4, half-maximal inhibitory concentration: 13200 nM
Compound 4: middle estimate off by 2.0-fold (0.31 log units), on the low side; the measured number lies above the stated range.
By their numbers in this assay, from the lowest: compounds 3, 2, 1 and 4 (each within the scatter of the next).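

In this assay, for the compounds shown here, this is the first pair that differs in one place only, and the swap of methyl for chloro on the aromatic carbon para to a large group gives a 1.7-fold higher number from compound 2 to compound 4 (0.23 log units; within the scatter). That step stays within the usual scatter, so this single swap on the 4-methylphenyl group of compound 2 does not separate the two compounds, and methyl and chloro cannot be told apart at this position on this read-out. Nothing measured here bears on why the two groups read alike.

Still open, going by these compounds, is whether a quite different group at the same place, such as an amine, a hydroxyl or a carboxylic acid, would give a step beyond the scatter. Also open, on these data alone, is whether the same swap from methyl to chloro would stay within the scatter on the core of compound 3, which differs from compound 2 in more than one place and so cannot be compared with it directly.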